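From chloro to bromo in a pair of inactive compounds

The source may hold more compounds than are shown below. What is called first, only, known or untested is meant among the compounds shown, and "the series" means these compounds.

Among the compounds with values here, compound 2 `Nc1nc(N2CCCC2)sc1C(=O)c1ccc(Cl)cc1` is one of two compounds measured in a functional assay on FM3A cells (Mus musculus) for antiproliferative activity, read by cell counting, with a stated time of 2 days; a lower number here means a stronger inhibitor, a higher number a weaker inhibitor. In this assay compound 2 gives only a limit, > 200000 nM. Compound 1 `COc1ccc(C(=O)c2sc(N3CCCC3)nc2N)cc1` likewise gives only a limit in this assay, > 200000 nM. Within the data shown here, the single measured step, a step that the two limits leave unreadable from compound 1 to compound 2, therefore cannot be read, as both values sit at the limit of > 200000 nM in this assay, at which 2 of the 2 values shown sit. Compound 3 `Nc1nc(N2CCCC2)sc1C(=O)c1ccc(Br)cc1` differs from compound 2 by bromo in place of chloro on an aromatic carbon. No readable measured step bears on this change, so no size or direction of step in this assay can be drawn from the numbers; the expectation for compound 3 is simply that it, too, remains at the limit, given (the limit of > 200000 nM in this assay, at which 2 of the 2 values shown sit). Compound 3 is therefore estimated at about 300000 nM in this assay, with a range from 150000 nM to 1000000 nM, which means an expected step that the limit leaves unreadable from compound 2 to compound 3 of essentially no change beyond the scatter.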

Compound 3, half-maximal inhibitory concentration: > 200000 nM
Compound 3 ended at the assay's limit (the forecaster's own chance of this, stated with the estimate: 85%); the middle value lies beyond the limit too.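

Within the data shown here, compound 3, like compound 1 and compound 2, gives only a limit in this assay, so no step among the three can be read: the limit of > 200000 nM in this assay, at which 3 of the 3 values shown sit. The compounds shown leave open how far each lies beyond that limit, and whether any other group at this place would give a measurable value.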